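A few compounds are considered here, and "the series" means these few. Any claim that something is new, unique, unknown or untested is made for them only; others in the source may bear on it.

Measured so far in an ADME assay on microsomes from liver (Homo sapiens) for metabolic stability, with a stated time of 60 min, tested at 10 uM; a lower number here means that less of the compound is left, a higher number that more of the compound is left:
- compound 1 `CCCS(=O)(=O)N1CCN(C2(CNC(=O)c3ccc(OC(F)(F)F)cc3)CCCCC2)CC1`: 11%
- compound 2 `CCCS(=O)(=O)N1CCN(C2(CNC(=O)c3cccc(C(F)(F)F)c3Cl)CCCCC2)CC1`: 1%

Compound 2, at 1%, cannot be told apart from compound 1, at 11%, since the two numbers lie within the usual scatter of repeated measurements. Little of either compound is left at the end of the test.

The next compound to be tested is compound 3 `CCCS(=O)(=O)N1CCN(C2(CNC(=O)c3c(Cl)cccc3Cl)CCCCC2)CC1`. It keeps the shared core and carries 2,6-dichlorophenyl in place of 2-chloro-3-(trifluoromethyl)phenyl on a carbonyl carbon.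

Going by the values given here, only one measured step bears on this change, because it swaps a group at the same place: a number 10 percentage points lower from compound 1 to compound 2 (within the scatter). That single swap stayed within the scatter, and no measured compound carries the 2,6-dichlorophenyl group, so the data give no reason to expect a real shift in this assay. The expected change is small, no step beyond the scatter: a number 5 percentage points higher from compound 2 to compound 3 (within the scatter).

For compound 3 the estimated value is 6%, with an expected range from 1% to 20%.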

Compound 3, percent of the compound remaining: 3%
Beside the measured number, compound 3's estimate is 3 percentage points above it, and the stated range covers the measured number.
By their numbers in this assay, from the lowest: compounds 2, 3 and 1 (each within the scatter of the next).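

In this assay, replacing 2-chloro-3-(trifluoromethyl)phenyl with 2,6-dichlorophenyl on the carbonyl carbon gives a number 2 percentage points higher from compound 2 to compound 3 (within the scatter) and so adds a third group that cannot be told apart from the second, while replacing 4-(trifluoromethoxy)phenyl with the same group gives a number 8 percentage points lower from compound 1 to compound 3 (within the scatter) and shows the same for the first. The entering group has fewer heavy atoms than the group it replaces and is the only one of the three without fluorine, yet neither difference comes with a step beyond the scatter, so across these three compounds the choice of substituted phenyl at this place has no measurable effect on how much compound is left. Nothing available explains these numbers or shows which part of the compounds is lost during the test.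

All three compounds carry a phenyl ring on the carbonyl carbon, leaving open whether a pyridine ring, a saturated cyclohexyl group or a phenyl ring bearing a carboxylic acid would behave differently. On these data alone, they also share the same core, so the effect of any change elsewhere in the molecule remains unknown.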